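Cytotoxicity of nitroaryl carbinols bearing a biphenyl arm

The source may hold more compounds than are shown below. What is called first, only, known or untested is meant among the compounds shown, and "the series" means these compounds.

Compound 1 `COc1cc(CC(O)c2ccc(-c3ccc(C#N)cc3)cc2)c([N+](=O)[O-])cc1OC` is tested in an ADME assay on HeLa Rh cells (Homo sapiens) for cytotoxicity, read by microscopy; a higher number here means that more compound is tolerated, a lower number that less compound is tolerated; compound 1 gives 4700 nM. Compound 2 `COc1cc(CC(O)c2ccc(-c3ccc(Cl)cc3)cc2)c([N+](=O)[O-])cc1OC` differs from compound 1 by chloro in place of cyano on an aromatic carbon and in this assay compound 2 gives 4100 nM. The step recorded is a 1.1-fold lower number from compound 1 to compound 2 (0.06 log units; within the scatter), so the two values are not distinguished by this assay.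

Compound 3 `COc1cc(CC(O)c2cccc(-c3ccc(C#N)cc3)c2)c([N+](=O)[O-])cc1OC` carries the same atoms as compound 1, joined differently; the difference between the two cores is not broken down here. In this assay compound 3 gives 9300 nM, which against compound 1 is within the scatter and against compound 2 is beyond it.

Compound 4 `COc1cc(CC(O)c2cccc(-c3ccc(Cl)cc3)c2)c([N+](=O)[O-])cc1OC` is not yet measured. It differs from compound 3 by chloro in place of cyano on an aromatic carbon, the same change already seen from compound 1 to compound 2, on the same kind of place. Since that earlier step was a 1.1-fold lower number from compound 1 to compound 2 (0.06 log units; within the scatter), the step from compound 3 to compound 4 is expected to be small, about a 1.1-fold lower number from compound 3 to compound 4 (0.04 log units; within the scatter). For compound 4 the estimate in this assay is 8500 nM, with a range from 4500 nM to 16000 nM.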

Compound 4, half-maximal cytotoxic concentration: 5000 nM
For compound 4 the middle estimate is 1.7-fold (0.23 log units) above the measured one, and the stated range covers the measured number.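

In this assay, going from 4-cyanophenyl to 4-chlorophenyl on the core of compound 3 gives a 1.9-fold lower number from compound 3 to compound 4 (0.27 log units; within the scatter). Set beside the earlier step on the core of compound 1, the change carries over without a difference that can be told apart: the same change on two cores in this assay, a 1.1-fold lower number (0.06 log units; within the scatter) from compound 1 to compound 2 and a 1.9-fold lower number (0.27 log units; within the scatter) from compound 3 to compound 4, 1.6-fold (0.21 log units) apart, within the scatter of two such steps. Two pairs are a narrow base, however, and with both steps within the scatter they do not show that the change shifts the tolerated concentration on either core, nor how it would behave on a further core.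

Still open, on these data alone, is how other groups would read at the place held by cyano and chloro, for instance an amine or a carboxylic acid. Every compound shown also carries the nitro group and the hydroxyl group, so what either contributes, set against an amine or a plain hydrogen in its stead, remains unknown.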